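The source may report more compounds than this note shows. Statements on the series, on what has been measured and on what is new or still open speak of the compounds shown alone.

Compound 1 `COC(=O)Nc1cc(-c2cc(Cl)c(OC[C@@](C)(N)CC(C)C)cn2)ccn1` stands highest of the three compounds measured: in an ADME assay on microsomes from liver (Mus musculus) for metabolic stability, read by LC-MS, using NADPH, with a stated time of 10 min, tested at 0.5 uM (on this read-out higher numbers stand for a more stable compound and lower numbers for a less stable compound), compound 1 gives 87%. Compound 2 `Cc1cc(-c2cc(Cl)c(OC[C@@](C)(N)CC(C)C)cn2)ccn1` gives 71% in this assay, and compound 3 `COC(=O)Nc1cc(-c2cnc(OC[C@@](C)(N)CC(C)C)c(OC)c2)ccn1` gives 59%. Going by the values given here, the one step between measured compounds that differ in a single place is a number 16 percentage points lower from compound 1 to compound 2 (beyond the scatter), a modest step that is beyond the usual scatter. Compound 4 `COC(=O)Nc1cc(-c2ccc(OC[C@@](C)(N)CC(C)C)cn2)ccn1` is the next compound in the series; it differs from compound 1 by hydrogen in place of chloro on an aromatic carbon. Among the compounds with values here, no measured step concerns this change at this position, so the expectation for compound 4 rests on compound 1 alone, with a small downward shift allowed for, and the step of a number 9 percentage points lower from compound 1 to compound 4 (within the scatter) is expected to lie within or only just beyond the scatter. Compound 4 is therefore estimated at 78% in this assay, in a range from 60% to 92%.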

Compound 4, percent of the compound remaining: 93%
Compound 4: middle estimate off by 15 percentage points, on the low side; the measured number lies above the stated range.
By their numbers in this assay, from the lowest: compound 3; then compound 2; then compounds 1 and 4 (each within the scatter of the next).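

With hydrogen in place of chloro on the aromatic carbon ortho to the (2-amino-2,4-dimethylpentyl)oxy group, this assay shows a number 6 percentage points higher from compound 1 to compound 4 (within the scatter), so this read-out does not separate the two compounds. The high number of compound 1 therefore does not depend on the chloro at this place. No measurement shown gives a reason for this result. Open, as far as these compounds go, is whether a fluoro or a nitrile on this carbon would stay in the same range, and whether this change would give a similar step with methyl in place of the (methoxycarbonyl)amino group.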